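Replacing an amide by an amine on the biaryl arm

A few compounds are considered here, and "the series" means these few. Any claim that something is new, unique, unknown or untested is made for them only; others in the source may bear on it.

Measured so far:
compound 1, `CNC(=O)c1cccc(-c2ccc(OC)c(S(=O)(=O)Nc3cccc(NCCNC(=O)c4ccccc4OC)c3)c2)c1`, 182 nM
compound 2, `COc1ccccc1C(=O)NCCNc1cccc(NS(=O)(=O)c2cc(-c3cccc(C(=O)N(C)C)c3)ccc2OC)c1`, 50 nM
compound 3, `COc1ccccc1C(=O)NCCNc1cccc(NS(=O)(=O)c2cc(-c3cccc(C(=O)N4CCC4)c3)ccc2OC)c1`, 235 nM

In an assay on CHO-K1 cells for agonist activity at Orexin receptor type 2 (Homo sapiens), read by a luciferase reporter (on this read-out higher numbers stand for an effect only at larger amounts of compound and lower numbers for an effect already at smaller amounts), compound 3 gives the highest number of the three. Its nearest neighbour is compound 1, with a 1.3-fold higher number from compound 1 to compound 3 (0.11 log units; within the scatter); its furthest is compound 2, with a 4.7-fold higher number from compound 2 to compound 3 (0.67 log units; beyond the scatter). Compound 4, `COc1ccccc1C(=O)NCCNc1cccc(NS(=O)(=O)c2cc(-c3cccc(N)c3)ccc2OC)c1`, differs from compound 3 in one place: amino in place of (azetidin-1-yl)carbonyl on an aromatic carbon.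

For the measured compounds named here, none of the measured steps covers this change. The steps seen, a 3.6-fold lower number from compound 1 to compound 2 (0.56 log units; beyond the scatter) and a 4.7-fold higher number from compound 2 to compound 3 (0.67 log units; beyond the scatter), only rearrange the substituents on the amide nitrogen, and they keep the carbonyl in place; their spread is modest. Removing the whole carbonyl-bearing group and leaving a bare amino group is a larger change than any of those, so the outcome is uncertain, and a step of at least modest size in either direction is possible.

Compound 4 is expected to come out with a somewhat higher number, an estimate of 450 nM with a range from 100 nM to 2500 nM, which would be a 1.9-fold higher number from compound 3 to compound 4 (0.28 log units; within the scatter).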

Compound 4, half-maximal effective concentration: > 1000 nM
Compound 4 gave a limit, no number (the forecaster's own chance of this, stated with the estimate: 10%); middle value at least 2.2-fold (0.34 log units) away from the limit.
By their numbers in this assay, from the lowest: compound 2; then compounds 1 and 3 (each within the scatter of the next). At a limit, above all of these: compound 4.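

The reading for compound 4 is a limit, not a number: the limit of > 1000 nM in this assay, at which 1 of the 4 values shown sits. Setting amino in place of the carbonyl-bearing group on this aromatic carbon gives a higher number against every amide shown, with steps of at least modest size (an at least 4.2-fold higher number from compound 3 to compound 4 (0.62 log units; beyond the scatter)) and (an at least 5.4-fold higher number from compound 1 to compound 4 (0.73 log units; beyond the scatter)) and a large one (an at least 20-fold higher number from compound 2 to compound 4 (1.30 log units; beyond the scatter)). The earlier compounds shown here varied only the substituents on the amide nitrogen, whereas this result shows that the carbonyl-bearing group as a whole counts at this position, whichever of the three amides it replaces.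

Going by these compounds, how far compound 4 lies beyond its limit stays open, so these steps are lower bounds only. Also open, on these data alone, is whether the loss of the amide or the arrival of the amino group drives the change, which plain hydrogen, an aminomethyl group or a carboxylic acid on this carbon could help separate.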